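Diaryl urea series: cytotoxicity notes before compound 4

The compounds below may be only part of what the source reports. "The series", "measured", "known", "first", "only" and "open" are said of these compounds alone.

Going by the values given here, compound 3 `Cc1cc(NC(=O)Nc2cccc(Cl)c2)c2ccccc2n1` is the one member with a number in an ADME assay on HepG2 cells (Homo sapiens) for cytotoxicity, with a stated time of 72 h (on this read-out lower numbers stand for an effect already at smaller amounts and higher numbers for an effect only at larger amounts of compound), where compound 3 gives 19000 nM. Compound 2 `Cc1cc(NC(=O)Nc2ccc(Cl)cc2)c2ccccc2n1` reaches only a limit of this assay, > 25000 nM. Compound 1 `COc1cccc(NC(=O)Nc2cc(C)nc3ccccc23)c1` likewise stops at a limit, > 25000 nM. The cores of compound 2 and compound 3 differ by 4-chlorophenyl in place of 3-chlorophenyl on an amide-type nitrogen, and the step is an at least 1.3-fold lower number from compound 2 to compound 3 (0.11 log units; that floor lies within the scatter). From compound 3 to compound 1 the change is methoxy in place of chloro on an aromatic carbon, with the step of an at least 1.3-fold higher number from compound 3 to compound 1 (0.11 log units; that floor lies within the scatter); both steps are bounded by the limit of > 25000 nM in this assay, at which 2 of the 3 values shown sit. Compound 4 `COc1ccc(NC(=O)Nc2cc(C)nc3ccccc23)cc1` is not yet measured; from compound 2 it differs by methoxy in place of chloro on an aromatic carbon, the same kind of change as from compound 3 to compound 1, though here sited para to a large group where the earlier one sits meta to a large group. Compound 2 already rests at the limit > 25000 nM. On that footing, and on the size of an at least 1.3-fold higher number from compound 3 to compound 1 (0.11 log units; that floor lies within the scatter), compound 4 is expected to show a step that the limit leaves unreadable from compound 2 to compound 4. The estimate for compound 4 is 35000 nM, expected between 18000 nM and 80000 nM.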

Compound 4, half-maximal effective concentration: > 25000 nM
Compound 4 gave a limit, no number; the forecaster's own chance of this, stated with the estimate: 75%; the middle value is on the limit's open side.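

Compound 4 stays at a limit, with no number, and compound 2 is also at a limit, so no step can be read from compound 2 to compound 4: the limit of > 25000 nM in this assay, at which 3 of the 4 values shown sit.

The compounds shown leave open whether methoxy in place of chloro on this aromatic carbon changes the number in this assay at all, and in which direction.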